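Chain-terminal methyl ester in place of the hydroxy group

This account rests on a few compounds, and the source may have more. Where it says the series, first, only, none or still open, it means among the compounds named here.

Compound 1 `CC(C)(C)C(=O)OCC1(CO)C/C(=C\CCCCCCCCCCCO)C(=O)O1` gives 1.09 ug/mL in a functional assay on K562 cells (Homo sapiens) for antiproliferative activity (a higher number here means a weaker inhibitor of growth, a lower number a stronger inhibitor of growth), the second highest of three numbers; compound 2 `CC(=O)OCCCCCCCCCCCCCCC/C=C1\CC(CO)(COC(=O)C(C)(C)C)OC1=O` gives 0.959 ug/mL, within the scatter of compound 1, while compound 3 `CC(=O)NCCCCCCCCCCCCCCC/C=C1\CC(CO)(COC(=O)C(C)(C)C)OC1=O` gives 3.38 ug/mL, the furthest from compound 1. Compound 4 `COC(=O)CCCCCCCCCCCCCC/C=C1\CC(CO)(COC(=O)C(C)(C)C)OC1=O` differs from compound 1 by 3-(methoxycarbonyl)propyl in place of hydroxy on a saturated chain carbon, ten or more bonds along the chain from a double-bonded chain carbon. The step of a 1.1-fold lower number from compound 1 to compound 2 (0.06 log units; within the scatter) bears most closely on this change, since an ester enters on the same chain there. The steps of a 3.1-fold higher number from compound 1 to compound 3 (0.49 log units; beyond the scatter) and a 3.5-fold higher number from compound 2 to compound 3 (0.55 log units; beyond the scatter) concern acetamido entering instead and are both modest. On this basis the expected step is a 1.1-fold higher number from compound 1 to compound 4 (0.04 log units; within the scatter), no more than the scatter. Compound 4 is therefore estimated at 1.2 ug/mL, with a range from 0.6 ug/mL to 2.5 ug/mL.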

Compound 4, concentration for 50% growth inhibition: 0.856 ug/mL
Estimate against measurement, compound 4: 1.4-fold (0.15 log units) above, within the range that was stated.
By their numbers in this assay, from the lowest: compounds 4, 2 and 1 (each within the scatter of the next); then compound 3.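

In this assay a chain-terminal methyl ester reads like the terminal hydroxy group, with a 1.3-fold lower number from compound 1 to compound 4 (0.10 log units; within the scatter) as the step. The ester also holds with its orientation on the chain reversed, since a 1.1-fold lower number from compound 2 to compound 4 (0.05 log units; within the scatter) also stays within the scatter. Compound 3 goes against this flat picture, and a 3.9-fold lower number from compound 3 to compound 4 (0.60 log units; beyond the scatter) shows that the acetamido end stands apart from this second ester as well as from the acetoxy end. No measured evidence on the compounds accounts for that gap. The series leaves open how a chain-terminal carboxylic acid or amine would read, and whether a longer chain would keep the ester's value.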